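The compounds below may be only part of what the source reports. "The series", "measured", "known", "first", "only" and "open" are said of these compounds alone.

Of the compounds shown here, three of this set have been measured in a functional assay on HEK293 cells for agonist activity at G-protein coupled receptor 39 (Homo sapiens), read by scintillation proximity assay and inositol phosphate accumulation, with a stated time of 75 min, in the presence of a further agent that is not named here; a higher number here means that more compound is needed for the effect, a lower number that less compound is needed. Compound 1, with the structure `Cc1noc(C)c1COC1CC(=O)Nc2c1c(C)nn2-c1ncnc2nc[nH]c12`, gives 5 nM in this assay. Compound 2, with the structure `CCC(C(=O)NC1CC(=O)Nc2c1c(C)nn2-c1ncnc2nc[nH]c12)c1ccccc1`, shares the same fused core and in this assay gives 5 nM, which is level with compound 1 at the digits shown and within the usual scatter of repeated measurements. Compound 3, with the structure `O=C1/C(=C/NCCCO)C(c2ccccc2)=NN1c1nc2ccccc2s1`, is built on a different skeleton and in this assay gives 200 nM, a number far higher than that of compound 1 and well beyond the scatter. Compound 1 therefore stands, together with compound 2, at the low end of the three numbers.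

The next compound, compound 4, has the structure `Cc1nn(-c2ncnc3nc[nH]c23)c2c1C(C(=O)N(C)c1nccs1)CC(=O)N2`. It keeps the core of compound 1 and changes one group on the saturated ring carbon: methyl(1,3-thiazol-2-yl)carbamoyl in place of (3,5-dimethyl-1,2-oxazol-4-yl)methoxy on a saturated ring carbon.

For the measured compounds named here, no directly comparable pair has been measured, so the size of this step is not known. Compound 2 shows that a carbonyl-bearing group at the same saturated ring carbon leaves the number unchanged, because compound 2 gives 5 nM, which sits within the scatter of compound 1. Compound 4 is therefore expected to land close to compound 1, with the step of a 2.0-fold higher number from compound 1 to compound 4 (0.30 log units; within the scatter) estimated as small. The estimated value for compound 4 in this assay is 10 nM, with a range from 2 nM to 50 nM.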

Compound 4, half-maximal effective concentration: 18 nM
Beside the measured number, compound 4's estimate is 1.8-fold (0.26 log units) below it; the measured number falls inside the stated range.
By their numbers in this assay, from the lowest: compounds 1 and 2 (each within the scatter of the next); then compound 4; then compound 3.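

For the compounds shown here, the swap to methyl(1,3-thiazol-2-yl)carbamoyl on the saturated ring carbon gives a 3.6-fold higher number from compound 1 to compound 4 (0.56 log units; beyond the scatter) in this assay, showing for the first time in a one-place comparison that the group at this carbon can shift the number, though the step is only modest. The two groups have the same heavy-atom count, the same counts of hydrogen-bond donors and acceptors, no net charge, and one five-membered aromatic ring with 2 hetero atoms each, so matching these counts does not guarantee the same number at this position. Nothing available explains the shift, so its cause remains unknown.

The entering and leaving groups differ in both the link to the saturated ring carbon and the aromatic ring they carry, and this single step cannot show how much each difference contributes. As far as these compounds go, it also remains open how the number would respond to a quite different group on this carbon, such as a simple amine, a carboxylic acid or a plain longer alkyl chain, and whether any such group would give a larger step than this one.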